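This account rests on a few compounds, and the source may have more. Where it says the series, first, only, none or still open, it means among the compounds named here.

Measured in a functional assay on MOLT-4 cells (Homo sapiens), with a stated time of 72 h; on this read-out higher numbers stand for weaker inhibition and lower numbers for stronger inhibition:
compound 1 `O=C1/C(=N\NC(=S)Nc2ccc(Cl)cc2)c2cc(F)ccc2N1Cc1ccc(F)cc1` — 47000 nM
compound 2 `O=C1/C(=N\NC(=S)Nc2ccc(Cl)cc2)c2cc(Cl)ccc2N1Cc1ccc(F)cc1` — 48000 nM

Of these two numbers, that of compound 2 is the larger, and the gap to compound 1 lies within the scatter. Compound 3 `O=C1/C(=N\NC(=S)Nc2ccc(Cl)cc2)c2cc(Br)ccc2N1Cc1ccc(F)cc1` differs from compound 2 by bromo in place of chloro on an aromatic carbon. Among the measured compounds shown here, the only step that bears on this change is a 1.0-fold higher number from compound 1 to compound 2 (0.01 log units; within the scatter), a halogen swap on the same aromatic carbon that stayed within the scatter. A second halogen swap there is therefore expected to give no step beyond the scatter in this assay, no change at the digits printed from compound 2 to compound 3 (within the scatter). Compound 3 is estimated at 48000 nM, with a range of 24000 nM to 96000 nM.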

Compound 3, half-maximal inhibitory concentration: 48000 nM
Compound 3: the middle estimate sits on the measured number at the digits printed, within the range that was stated.
By their numbers in this assay, from the lowest: compounds 1, 2 and 3 (each within the scatter of the next).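

In this assay bromo on this aromatic carbon gives no change at the digits printed from compound 2 to compound 3 (within the scatter) and, read against the fluoro compound, a 1.0-fold higher number from compound 1 to compound 3 (0.01 log units; within the scatter) so this change extends the earlier fluoro-to-chloro comparison to three halogens, all within the scatter of one another. At this position, the assay does not separate these halogens. No measured evidence offers an explanation for this.

As far as these compounds go, whether this holds beyond halogens stays open: an amine, a methoxy group or a carboxylic acid on this carbon could behave differently. From the compounds shown here alone, the rest of the shared core stays fixed, so its contribution is also open.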